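Swapping Fluorine for Chlorine on a Shared Core

The source may report more compounds than this note shows. Statements on the series, on what has been measured and on what is new or still open speak of the compounds shown alone.

Of the compounds shown here, three built on one shared core have been tested in a functional assay on U-251 cells (Homo sapiens) for inhibition, read by sulforhodamine B assay, with a stated time of 48 h, tested at 10 uM; a lower number here means less inhibition, a higher number more inhibition at the concentration tested (going by the name of the read-out). Compound 1 `Brc1cn2ccnc2c(-c2ccc3ncn(C4CCCCC4)c3c2)n1` gives 1.5%, compound 2 `COc1ccc(-c2cn3ccnc3c(-c3ccc4ncn(C5CCCCC5)c4c3)n2)cc1` gives 80.9%, and compound 3 `Fc1ccc(-c2cn3ccnc3c(-c3ccc4ncn(C5CCCCC5)c4c3)n2)cc1` gives 7.94%. Compound 3 thus sits within the scatter of compound 1 and far below compound 2. Compound 4 `Clc1ccc(-c2cn3ccnc3c(-c3ccc4ncn(C5CCCCC5)c4c3)n2)cc1` differs from compound 3 by chloro in place of fluoro on an aromatic carbon. Among the measured compounds shown here, no measured step exchanges one halogen for another. The nearest comparisons are a number 6.4 percentage points higher from compound 1 to compound 3 (within the scatter), a small step, and a number 73 percentage points lower from compound 2 to compound 3 (beyond the scatter), a large one. Chloro and fluoro are both single halogen atoms. The expected step for compound 4 is therefore modest, a number 6.1 percentage points higher from compound 3 to compound 4 (within the scatter). Compound 4 is estimated at 14%, between 2% and 40%.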

Compound 4, a percentage reported as inhibition, at one concentration (the size of the read-out at that concentration, not a potency): 11.3%
Beside the measured number, compound 4's estimate is 2.7 percentage points above it; measured number inside the range.
By their numbers in this assay, from the lowest: compounds 1, 3 and 4 (each within the scatter of the next); then compound 2.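

In this assay, among the compounds shown here, the first exchange of one halogen for another at this position gives no readable change (a number 3.4 percentage points higher from compound 3 to compound 4 (within the scatter)). The 4-chlorophenyl compound also stays level with the bromo compound (a number 9.8 percentage points higher from compound 1 to compound 4 (within the scatter)), while the methoxy compound stands well apart (a number 69.6 percentage points lower from compound 2 to compound 4 (beyond the scatter)). Nothing available explains why methoxy differs so much from the halogens.

Still open, going by these compounds, is whether the high number belongs to methoxy alone, or whether an ethoxy, a hydroxyl or an amine in the same place would also give it.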